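Adding a methoxy group beside the ring hydroxyl of compound 2

A few compounds are considered here, and "the series" means these few. Any claim that something is new, unique, unknown or untested is made for them only; others in the source may bear on it.

Compound 1 `O=C(C/C=C/c1ccc(O)cc1)OC[C@@]1(O)CO[C@@H](O[C@H]2[C@H](OCCc3ccc(O)cc3)O[C@H](CO)[C@@H](O)[C@@H]2O)[C@@H]1O`: 4500 nM
Compound 2 `O=C(OC[C@@]1(O)CO[C@@H](O[C@H]2[C@H](OCCc3ccc(O)cc3)O[C@H](CO)[C@@H](O)[C@@H]2O)[C@@H]1O)c1ccc(O)cc1`: 36200 nM

In a functional assay for inhibition, read by fluorescence, with a stated time of 5 min, in the presence of a further agent that is not named here (a lower number here means a stronger inhibitor, a higher number a weaker inhibitor), compound 1 gives 4500 nM and compound 2 gives 36200 nM. Compound 2 therefore stands at the highest, weakest, number of the two, with an 8.0-fold higher number from compound 1 to compound 2 (0.91 log units; beyond the scatter) separating it from compound 1. Compound 3 `COc1cc(C(=O)OC[C@@]2(O)CO[C@@H](O[C@H]3[C@H](OCCc4ccc(O)cc4)O[C@H](CO)[C@@H](O)[C@@H]3O)[C@@H]2O)ccc1O` differs from compound 2 by methoxy in place of hydrogen on an aromatic carbon. Among the compounds with values here, no measured step involves a methoxy group, so nothing in these data points to a direction for this change. Compound 3 is expected to sit close to compound 2, with a 1.0-fold lower number from compound 2 to compound 3 (0.00 log units; within the scatter) within the usual scatter, giving an estimate of 36000 nM in this assay, within a range of 12000 nM to 110000 nM.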

Compound 3, half-maximal inhibitory concentration: 8600 nM
Beside the measured number, compound 3's estimate is 4.2-fold (0.62 log units) above it; the measured number lies below the stated range.
By their numbers in this assay, from the lowest: compounds 1 and 3 (each within the scatter of the next); then compound 2.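

In this assay a methoxy group on the aromatic carbon ortho to the hydroxy group is not a silent addition, giving a 4.2-fold lower number from compound 2 to compound 3 (0.62 log units; beyond the scatter) and showing that this ring position affects the result. The 4-hydroxy-3-methoxyphenyl group closes the earlier gap, with a 1.9-fold higher number from compound 1 to compound 3 (0.28 log units; within the scatter) as the step to the 3-(4-hydroxyphenyl)prop-2-en-1-yl compound. No measurement shown explains this change. From the compounds shown here alone, whether an ethoxy group, a hydroxy group or a chlorine atom at this carbon would act in the same way remains open, as does the effect of adding a methoxy group to the ring of compound 1.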